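A few compounds are considered here, and "the series" means these few. Any claim that something is new, unique, unknown or untested is made for them only; others in the source may bear on it.

Measured in a functional assay on MCF7 cells (Homo sapiens) for antiproliferative activity, read by MTT assay, with a stated time of 24 h; a higher number here means a weaker inhibitor, a lower number a stronger inhibitor:
- compound 1 `COc1ccc(-c2noc(-c3ccccc3)n2)cc1OC1CCCC1`: > 1000000 nM (a limit)
- compound 2 `COc1ccc(-c2noc(C3CCCN3)n2)cc1OC1CCCC1`: > 1000000 nM (a limit)
- compound 3 `COc1ccc(-c2noc(-c3ccc(F)cc3)n2)cc1OC1CCCC1`: 3880 nM

Compound 3 is the only one of the three with an actual number, at 3880 nM. The other two results are limits, as the record shows: the limit of > 1000000 nM in this assay, at which 2 of the 3 values shown sit.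

Compound 4 `COc1ccc(-c2noc(-c3cccnc3)n2)cc1OC1CCCC1` has not yet been measured. It carries pyridin-3-yl in place of 4-fluorophenyl on an aromatic carbon of the five-membered aromatic ring with 2 nitrogen and 1 oxygen, and the counted difference is pyridin-3-yl in place of 4-fluorophenyl on an aromatic carbon.

The closest measured step is an at least 250-fold lower number from compound 1 to compound 3 (2.41 log units; beyond the scatter), which came with fluoro in place of hydrogen. The second relevant step, also large, is an at least 250-fold lower number from compound 2 to compound 3 (2.41 log units; beyond the scatter), which introduced 4-fluorophenyl in place of pyrrolidin-2-yl. Neither step tests pyridin-3-yl directly, and the step between the two limits cannot be read. Resting on an at least 250-fold lower number from compound 1 to compound 3 (2.41 log units; beyond the scatter), a clearly higher number is expected in this assay once the 4-fluorophenyl leaves, with a real chance of another limit. The expected step is a 10-fold higher number from compound 3 to compound 4 (1.01 log units; beyond the scatter). Compound 4 is estimated at 40000 nM, with an expected range of 3000 nM to 600000 nM.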

Compound 4, half-maximal inhibitory concentration: > 1000000 nM
Compound 4 was reported as a limit; the forecaster's own chance of this, stated with the estimate: 35%; middle value at least 25-fold (1.39 log units) from the limit.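

Replacing 4-fluorophenyl with pyridin-3-yl on the aromatic carbon of the five-membered aromatic ring with 2 nitrogen and 1 oxygen gave, in this assay, an at least 250-fold higher number from compound 3 to compound 4 (2.41 log units; beyond the scatter). Compound 1 had already shown that phenyl gives no number; compound 4 shows that a six-membered aromatic ring with a hetero atom gives none either, so among the groups shown only 4-fluorophenyl yields one. The result for compound 4 is itself a limit, and its steps to compound 1 and compound 2 cannot be read: the limit of > 1000000 nM in this assay, at which 3 of the 4 values shown sit.

As far as these compounds go, whether chloro or methoxy in place of the fluoro of 4-fluorophenyl, or an amine there, would also give a number stays open. The compounds shown also leave open how compound 1, compound 2 and compound 4 rank among themselves.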